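From pyrrolidin-1-yl to piperidin-1-yl on a sulfonyl sulfur

The source may report more compounds than this note shows. Statements on the series, on what has been measured and on what is new or still open speak of the compounds shown alone.

Two related compounds have been measured so far in an ADME assay on cells (Hepatocyte, Mus musculus) for metabolic stability, read by LC-MS, tested at 1 uM; a lower number here means that less of the compound is left, a higher number that more of the compound is left. Compound 1 (`Cc1ccnc(NC(=O)c2ccsc2NC(=O)c2ccc(S(=O)(=O)N3CCCCC3)cc2)n1`) gives 7.3%, while compound 2 (`CCOC(=O)NC(=O)c1ccsc1NC(=O)c1ccc(S(=O)(=O)N2CCCC2)cc1`) gives 49.7%. Compound 2 therefore stands as the higher of the two, and the gap between them lies beyond the usual scatter of repeated measurements. Compound 3 (`CCOC(=O)NC(=O)c1ccsc1NC(=O)c1ccc(S(=O)(=O)N2CCCCC2)cc1`) is the same as compound 2 except in one place: it has piperidin-1-yl in place of pyrrolidin-1-yl on a sulfonyl sulfur. Among the measured compounds shown here, no measured pair of compounds shows this single change alone, so any forecast here is a judgement. Compound 1 also carries piperidin-1-yl on a sulfonyl sulfur, and its value of 7.3% tilts the expectation downward. That hint is weak, since compound 1 also differs from compound 2 elsewhere in its structure. A moderate drop in this assay is therefore expected, an estimated a number 13.7 percentage points lower from compound 2 to compound 3 (beyond the scatter). For compound 3 the estimated value is 36%, with an expected range from 17% to 55%.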

Compound 3, percent of the compound remaining: 66.3%
Estimate against measurement, compound 3: 30.3 percentage points below; measured number outside the range, above it.
By their numbers in this assay, from the lowest: compound 1; then compound 2; then compound 3.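

With the ethoxycarbonyl group held on the amide-type nitrogen, the change on the sulfonyl sulfur can now be read alone in this assay: piperidin-1-yl in place of pyrrolidin-1-yl gives a number 16.6 percentage points higher from compound 2 to compound 3 (beyond the scatter) and is a modest step. The low number of compound 1 therefore does not follow from piperidin-1-yl alone, since a compound with this same group on the sulfonyl sulfur can keep a high number. With piperidin-1-yl held fixed, ethoxycarbonyl in place of 4-methylpyrimidin-2-yl on an amide-type nitrogen gives a number 59 percentage points higher from compound 1 to compound 3 (beyond the scatter) and is a large step, so among these compounds the bigger shift goes with the group on that nitrogen.

Nothing shown here explains why either change leaves more of the compound intact. On these data alone, it also stays open whether the gain from piperidin-1-yl holds with 4-methylpyrimidin-2-yl on the amide-type nitrogen, and what a morpholine ring or an open-chain diethylamino group on the sulfonyl sulfur would give.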